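A few compounds are considered here, and "the series" means these few. Any claim that something is new, unique, unknown or untested is made for them only; others in the source may bear on it.

Measured so far in an ADME assay on HEK293 cells (Homo sapiens) for cytotoxicity, read by luminescence, with a stated time of 72 h (on this read-out higher numbers stand for an effect only at larger amounts of compound and lower numbers for an effect already at smaller amounts), are two compounds:
- Compound 1 `CCOC(=O)c1c(-c2cccc(-c3ccccc3)c2)[nH]c2cc(OC)c(F)cc2c1=O` gives > 22000 nM as a limit
- Compound 2 `CCOC(=O)c1c(-c2cccc(OC)c2)[nH]c2cc(OC)c(F)cc2c1=O` gives > 22000 nM as a limit

Among the compounds with values here, compound 2 therefore stands at a limit and has no exact number of its own in this assay so far. Both compounds share this position: the limit of > 22000 nM in this assay, at which 2 of the 2 values shown sit, is the whole of the evidence.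

Compound 3 `CCOC(=O)c1c(-c2cccc(Oc3ccccc3)c2)[nH]c2cc(OC)c(F)cc2c1=O` makes one change to compound 2: phenyl in place of methyl on an oxygen on an aromatic ring puts phenyl in place of methyl on an oxygen on an aromatic ring, turning methoxy into phenoxy.

Within the data shown here, the only measured step that bears on this is a step that the two limits leave unreadable from compound 1 to compound 2 and it placed methoxy in place of phenyl on an aromatic carbon. Its size cannot be read, so it offers no direction. Compound 1 nevertheless carries a phenyl group and gives > 22000 nM as a limit as well. No step beyond the usual scatter is therefore expected in this assay in either direction. The expected change is a number no higher from compound 2 to compound 3 (the limit leaves the size open) and so no real shift. Compound 3 is estimated at 22000 nM with an expected range from 11000 nM to 45000 nM and it may well return only a limit again.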

Compound 3, half-maximal effective concentration: > 22000 nM
Compound 3 was reported as a limit (the forecaster's own chance of this, stated with the estimate: 85%); the middle value sits exactly at the limit.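

No step among compound 1, compound 2 and compound 3 can be read in this assay, as each result is a limit and not a number: the limit of > 22000 nM in this assay, at which 3 of the 3 values shown sit.

The compounds shown leave open whether phenyl, methoxy and phenoxy differ in their effect on these cells, and at what concentration any of the three compounds would produce one.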